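Three limits and a change of aryl group

This account rests on a few compounds, and the source may have more. Where it says the series, first, only, none or still open, it means among the compounds named here.

compound 1 `CCn1cc(C(=O)N2N=C(c3cc4ccccc4o3)CC2c2ccccc2C(=O)O)c(=O)c2ccc(C)nc21`: > 196000 nM
compound 2 `CCn1cc(C(=O)N2N=C(c3cc4ccccc4o3)CC2c2cccc([N+](=O)[O-])c2)c(=O)c2ccc(C)nc21`: > 164000 nM
compound 3 `CCn1cc(C(=O)N2N=C(c3cc4ccccc4o3)CC2c2ccc(O)cc2)c(=O)c2ccc(C)nc21`: > 148000 nM

All three measured compounds share one core and differ only in the aryl group on a saturated ring carbon. In an ADME assay on Vero cells (Chlorocebus sabaeus) for cytotoxicity, read by MTT assay, with a stated time of 72 h (a lower number here means a stronger inhibitor, a higher number a weaker inhibitor), compound 1 gives > 196000 nM, which is a limit of the assay rather than a number. Compound 2 gives > 164000 nM in this assay, again a limit. Compound 3 likewise gives > 148000 nM, a limit. Compound 3 therefore stands at a limit, and the two other values shown are limits as well: the limit of > 148000 nM in this assay, at which 1 of the 3 values shown sits, the limit of > 164000 nM in this assay, at which 1 of the 3 values shown sits, and (the limit of > 196000 nM in this assay, at which 1 of the 3 values shown sits). As a result, the three steps between measured compounds cannot be read: a step that the two limits leave unreadable from compound 1 to compound 2, a step that the two limits leave unreadable from compound 1 to compound 3 and a step that the two limits leave unreadable from compound 2 to compound 3.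

Compound 4 `CCn1cc(C(=O)N2N=C(c3cc4ccccc4o3)CC2c2ccccc2[N+](=O)[O-])c(=O)c2ccc(C)nc21` is not yet measured. It differs from compound 3 as follows: 2-nitrophenyl in place of 4-hydroxyphenyl on a saturated ring carbon. The step most like this one is the unreadable step from compound 2 to compound 3, which also exchanges a nitrophenyl for a hydroxyphenyl, so no size or direction can be taken from the data, and no step beyond the scatter is expected. Compound 4 is thus expected to give about 200000 nM in this assay, most likely as a limit, within 100000 nM to 400000 nM, which means an expected step that the limit leaves unreadable from compound 3 to compound 4.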

Compound 4, half-maximal inhibitory concentration: > 85400 nM
Compound 4: a limit, no number; the forecaster's own chance of this, stated with the estimate: 85%; the middle value does not contradict the limit.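

Compound 4, like compound 1, compound 2 and compound 3, gives only a limit in this assay, and the steps to compound 4 from each of these three cannot be read. The compounds shown leave open how large any difference between these aryl groups is, and whether any of them on the shared core would give a number rather than a limit.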